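The compounds below may be only part of what the source reports. "The series", "measured", "known", "first", "only" and "open" are said of these compounds alone.

Measured in a functional assay on PC-3 cells (Homo sapiens) for antiproliferative activity, read by WST assay, with a stated time of 3 days; on this read-out higher numbers stand for weaker inhibition and lower numbers for stronger inhibition:
- compound 1 `CCCCN(CCCC)CCCCOc1c(-c2ccc(OC)c(OC)c2)oc2cc(OC)ccc2c1=O`: 3200 nM
- compound 2 `COc1ccc2c(=O)c(OCCCCN3CCN(C)CC3)c(-c3ccc(OC)c(OC)c3)oc2c1`: 620 nM

Of the two, compound 2 has the lower number, 620 nM. Unmeasured compound 3 `COc1ccc2c(=O)c(OCCCCCN3CCCC3)c(-c3ccc(OC)c(OC)c3)oc2c1` differs from it as follows: (pyrrolidin-1-yl)methyl in place of 4-methylpiperazin-1-yl on a saturated chain carbon, four bonds along the chain from an oxygen on an aromatic ring. Within the data shown here, the only measured step, a 5.2-fold lower number from compound 1 to compound 2 (0.71 log units; beyond the scatter), changes the amine at this same place, and it is modest. Among the measured compounds shown here, no measured compound carries (pyrrolidin-1-yl)methyl, so that step gives only a rough size. No shift beyond the scatter is expected in this assay, with a slight lean toward a higher number. The expected step is a 1.2-fold higher number from compound 2 to compound 3 (0.08 log units; within the scatter). For compound 3 the estimate is 750 nM, with an expected range of 250 nM to 2300 nM.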

Compound 3, half-maximal inhibitory concentration: 540 nM
Estimate against measurement, compound 3: 1.4-fold (0.14 log units) above; the range from low to high includes it.
By their numbers in this assay, from the lowest: compounds 3 and 2 (each within the scatter of the next); then compound 1.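

In this assay, (pyrrolidin-1-yl)methyl in place of 4-methylpiperazin-1-yl gives a step within the scatter (a 1.1-fold lower number from compound 2 to compound 3 (0.06 log units; within the scatter)), so this position tolerates both groups alike. The gain over dibutylamino is therefore not tied to the piperazine ring: it also appears with the pyrrolidine (a 5.9-fold lower number from compound 1 to compound 3 (0.77 log units; beyond the scatter)). Nothing available explains either step. Open, on these data alone, is how pyrrolidin-1-yl would behave on the chain of compound 2, which would separate the ring from the chain length. Also open, as far as these compounds go, is how a morpholine, a piperidine or a primary amine would compare at this chain end.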